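This account rests on a few compounds, and the source may have more. Where it says the series, first, only, none or still open, it means among the compounds named here.

Measured in a functional assay on the whole organism (Tail, strain ICR) with Mus musculus as the target, in the tail flick test, with a stated time of 60 min, at a dose of 25 umol/kg by the oral route; on this read-out lower numbers stand for a weaker effect and higher numbers for a stronger effect at the one dose given:
compound 1 `N=C(N)NCCC[C@H](NC(=O)CN(c1nc(Cl)nc2[nH]cnc12)C1CC1)C(=O)OCc1ccccc1` gives 30.6%
compound 2 `O=C(CN(c1nc(Cl)nc2[nH]cnc12)C1CC1)N[C@@H](CC(=O)OCc1ccccc1)C(=O)OCc1ccccc1` gives 22.4%
compound 3 `NC(=O)CC[C@H](NC(=O)CN(c1nc(Cl)nc2[nH]cnc12)C1CC1)C(=O)O` gives 38.4%

Compound 3 holds the highest of the three numbers; its gap to compound 1 lies within the scatter, its gap to compound 2 beyond it. Compound 4 `NC(=O)CC[C@H](NC(=O)CN(c1nc(Cl)nc2[nH]cnc12)C1CC1)C(=O)OCc1ccccc1` is not yet measured. The change from compound 3 to compound 4 is benzyl in place of hydrogen on an oxygen next to a carbonyl group. Within the data shown here, only one step between measured compounds is available, a number 8.2 percentage points lower from compound 1 to compound 2 (within the scatter), and it concerns a different group, so no measured pair shows this exact change. Compounds 1 and 2, which each carry a benzyloxycarbonyl group, give numbers close to that of compound 3. In this assay the expectation for compound 4 is therefore no step beyond the scatter, a number 5.4 percentage points lower from compound 3 to compound 4 (within the scatter). The estimate for compound 4 is 33%, with a range from 18% to 50%.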

Compound 4, a percentage reported as activity, at one dose (the size of the read-out at that dose, not a potency): 33.1%
The estimate for compound 4 lay 0.1 percentage points below the measured number; low and high end bracket the measured number.
By their numbers in this assay, from the lowest: compounds 2, 1, 4 and 3 (each within the scatter of the next, the first and the last beyond it).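

In this assay, among these compounds, carboxy to benzyloxycarbonyl, benzyl on an oxygen next to a carbonyl group, gives a number 5.3 percentage points lower from compound 3 to compound 4 (within the scatter), so this change alone produces no step that stands out from the scatter. With the benzyloxycarbonyl kept, carbamoylmethyl in place of benzyloxycarbonyl on the saturated chain carbon gives a number 10.7 percentage points higher from compound 2 to compound 4 (beyond the scatter), a modest step, whereas the exchange of one group for another on a saturated chain carbon gives a number 2.5 percentage points higher from compound 1 to compound 4 (within the scatter). Nothing at hand speaks to the cause of these steps.

On these data alone, a methyl ester on this oxygen remains open, as does a primary amine on the saturated chain carbon. A single dose and time give no potency for any of these compounds.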